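This account rests on a few compounds, and the source may have more. Where it says the series, first, only, none or still open, it means among the compounds named here.

Compound 1 `Cc1ccc(N/N=C2\CCC(C)n3c2ncc(C(=O)O)c3=O)cc1`: in a functional assay on the whole organism for inhibition, with Rattus norvegicus as the target (a lower number here means that less compound is needed, a higher number that more compound is needed for the effect), compound 1 gives 1.3 umol/kg.
Compound 2 `CC1CC/C(=N\Nc2ccc(C(F)(F)F)cc2)c2ncc(C(=O)O)c(=O)n21`: in this assay compound 2 gives 38.6 umol/kg.
Compound 3 `CC1CC/C(=N\Nc2ccc([N+](=O)[O-])cc2)c2ncc(C(=O)O)c(=O)n21`: in this assay compound 3 gives 0.8 umol/kg.

Compound 3 has the lowest of the three numbers in this assay. Compound 1 stands nearest to it, as the step of a 1.6-fold lower number from compound 1 to compound 3 (0.21 log units; within the scatter) shows, and compound 2 stands furthest, as the step of a 48-fold lower number from compound 2 to compound 3 (1.68 log units; beyond the scatter) shows; between those two, a 30-fold higher number from compound 1 to compound 2 (1.47 log units; beyond the scatter).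

Compound 4 `CC(C)c1ccc(N/N=C2\CCC(C)n3c2ncc(C(=O)O)c3=O)cc1` differs from compound 3 in one place: isopropyl in place of nitro on an aromatic carbon. Within the data shown here, two measured steps bear on this. The closer one is the step from compound 1 to compound 3, where methyl, a carbon-only group like the entering isopropyl, stood on the same aromatic carbon and the exchange for nitro stayed within the scatter. The step from compound 2 to compound 3 warns that another group on that carbon moved the number a long way, so the outcome is not assured. The expectation for compound 4 is a small rise, a 2.5-fold higher number from compound 3 to compound 4 (0.40 log units; beyond the scatter), not clearly beyond the scatter. Compound 4 is therefore estimated at 2 umol/kg, with a range from 0.7 umol/kg to 8 umol/kg.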

Compound 4, dose for 50% inhibition: 2.4 umol/kg
The estimate for compound 4 lay 1.2-fold (0.08 log units) below the measured number, within the range that was stated.
By their numbers in this assay, from the lowest: compounds 3, 1 and 4 (each within the scatter of the next, the first and the last beyond it); then compound 2.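

With isopropyl on this aromatic carbon, para to a large group, this assay now separates two groups that each stood close to methyl: a 3.0-fold higher number from compound 3 to compound 4 (0.48 log units; beyond the scatter) is a modest step beyond the scatter, while a 1.8-fold higher number from compound 1 to compound 4 (0.27 log units; within the scatter) stays within it. Among these compounds, replacing trifluoromethyl with this branched carbon-only group gives a much larger change, a 16-fold lower number from compound 2 to compound 4 (1.21 log units; beyond the scatter), so a second group joins methyl and nitro well away from trifluoromethyl, the one compound of the four that stands far off. Nothing available here accounts for that separation.

The compounds shown leave open whether a basic amine, a methoxy group or a chlorine atom on this carbon would fall with these three groups or nearer to trifluoromethyl. They also leave open whether a longer carbon chain would keep the number close to that of compound 4.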